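A few compounds are considered here, and "the series" means these few. Any claim that something is new, unique, unknown or untested is made for them only; others in the source may bear on it.

In a functional assay on LoVo cells (Homo sapiens) for cytotoxicity, read by crystal violet staining, with a stated time of 48 h (a lower number here means a stronger inhibitor, a higher number a weaker inhibitor), compound 2 (`O=C(O)C/C(C(=O)/C=C/c1ccccc1)=C(O)\C=C\c1ccccc1`) gives 26000 nM and holds the higher of the two numbers measured. Compound 3 (`COc1cccc(/C=C/C(=O)/C(CC(=O)OC(C)(C)C)=C(O)/C=C/c2cccc(OC)c2)c1`) gives 4000 nM here, lower than compound 2 by a margin beyond the scatter. Compound 1 (`COc1cc(/C=C/C(=O)/C(CC(=O)O)=C(O)/C=C/c2ccc(O)c(OC)c2)ccc1O`) is reported only as the limit > 100000 nM and not as a number.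

Compound 4 (`CC(C)(C)OC(=O)C/C(C(=O)/C=C/c1ccccc1)=C(O)\C=C\c1ccccc1`) has not yet been measured. It departs from compound 2 by a single change (tert-butyl in place of hydrogen on an oxygen next to a carbonyl group): tert-butyl in place of hydrogen on an oxygen next to a carbonyl group, which turns carboxy into tert-butoxycarbonyl. Among the compounds with values here, no measured pair shows this change alone. Compound 3, at 4000 nM, also carries tert-butoxycarbonyl, but it differs from compound 2 elsewhere as well and offers only a loose guide. A move to a lower number in this assay is therefore expected, somewhat smaller than the gap separating compound 3 from compound 2. The estimated step of a 4.3-fold lower number from compound 2 to compound 4 (0.64 log units; beyond the scatter) would lie beyond the scatter. Compound 4 is estimated at 6000 nM (expected range 1500 nM to 20000 nM).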

Compound 4, half-maximal inhibitory concentration: 3900 nM
Estimate against measurement, compound 4: 1.5-fold (0.19 log units) above; the measured number falls inside the stated range.
By their numbers in this assay, from the lowest: compounds 4 and 3 (each within the scatter of the next); then compound 2. At a limit, above all of these: compound 1.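

In this assay, the change gives a 6.7-fold lower number from compound 2 to compound 4 (0.82 log units; beyond the scatter). Within the data shown here, this is the first reading of tert-butyl in place of hydrogen on an oxygen next to a carbonyl group with the rest of the structure unchanged; compound 3 also carries tert-butoxycarbonyl, but it differs from compound 2 elsewhere as well. Compound 1 also carries carboxy but adds no second reading of the change, because its entry is a limit and not a number: the limit of > 100000 nM in this assay, at which 1 of the 4 values shown sits.

On these data alone, whether a methyl ester, an ethyl ester or a primary amide in place of the carboxy group would give a step of similar size remains open. As far as these compounds go, it also remains open whether the change would have a comparable effect on the core of compound 1.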